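The source may report more compounds than this note shows. Statements on the series, on what has been measured and on what is new or still open speak of the compounds shown alone.

Working notes on the series, read in a functional assay on MX1 cells (Homo sapiens) for inhibition, read by MTT assay, with a stated time of 120 h; a lower number here means a stronger inhibitor, a higher number a weaker inhibitor. Compound 1 `CC(NC(=O)/C=C/c1ccc(NC(=O)Nc2ccc(Cl)c(C(F)(F)F)c2)cc1)c1ccccc1` gives 3130 nM, and compound 2 `CC(NC(=O)C#Cc1ccc(NC(=O)Nc2ccc(Cl)c(C(F)(F)F)c2)cc1)c1ccccc1` gives 12800 nM, the higher of these two values. Compound 3 `CC(NC(=O)CCc1ccc(NC(=O)Nc2ccc(Cl)c(C(F)(F)F)c2)cc1)c1ccccc1` keeps the 1-phenylethyl group of compound 1 and compound 2. Compound 3 reads > 50000 nM. That reading is a limit of the assay and not a number. Going by the values given here, it is the only such reading so far, which places compound 3 at the limit of > 50000 nM in this assay, at which 1 of the 3 values shown sits.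

The next compound is compound 4 `CNC(=O)CCc1ccc(NC(=O)Nc2ccc(Cl)c(C(F)(F)F)c2)cc1`, with methyl in place of 1-phenylethyl on an amide-type nitrogen. Among the compounds with values here, no measured pair differs in one place, so the size of this change has no direct precedent in this assay. The expectation rests only on compound 3, whose reading of > 50000 nM leaves no measured baseline. No gain in strength is expected, and the most likely outcome is another reading at the limit. The expected move, a number no higher from compound 3 to compound 4 (the limit leaves the size open), is none beyond the scatter. For compound 4 the estimated value is 50000 nM, with an expected range from 20000 nM to 100000 nM.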

Compound 4, half-maximal inhibitory concentration: 20400 nM
Estimate against measurement, compound 4: 2.5-fold (0.39 log units) above; measured number inside the range.
By their numbers in this assay, from the lowest: compound 1; then compounds 2 and 4 (each within the scatter of the next). At a limit, above all of these: compound 3.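

In this assay, going by these compounds alone, the exchange of 1-phenylethyl for methyl on the amide-type nitrogen gives an at least 2.4-fold lower number from compound 3 to compound 4 (0.38 log units; beyond the scatter) and is the first step that can be read across a single place. With methyl on this nitrogen, compound 4 reads 20400 nM and so returns a number, which shows that a measurable reading on the shared core of compound 3 and compound 4 does not depend on 1-phenylethyl. The reading of compound 3 is a limit of the assay and not a number, so the step sets a floor and does not fix the full size of the change: the limit of > 50000 nM in this assay, at which 1 of the 4 values shown sits.

The compounds shown leave open whether the same exchange would carry the same weight on the core of compound 1 or compound 2, where the amide nitrogen also bears 1-phenylethyl. They also leave open how the reading would respond to other groups on this nitrogen, such as ethyl, benzyl, a plain unsubstituted amide or a longer chain ending in an amine or a carboxylic acid.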